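Dimethoxy substitution on the sulfonyl aryl of compound 3

A few compounds are considered here, and "the series" means these few. Any claim that something is new, unique, unknown or untested is made for them only; others in the source may bear on it.

Three compounds sharing one core have numbers in a functional assay on HL-60 cells (Homo sapiens) for antiproliferative activity, read by MTT assay, with a stated time of 72 h; on this read-out higher numbers stand for weaker inhibition and lower numbers for stronger inhibition. Compound 1 `CCC(=O)N(C)c1ccc2[nH]c(-c3n[nH]c4ccccc34)cc2n1` gives 6130 nM; compound 2 `CN(C(=O)c1ccc(Cl)cc1)c1ccc2[nH]c(-c3n[nH]c4ccccc34)cc2n1` gives 450 nM; compound 3 `CN(c1ccc2[nH]c(-c3n[nH]c4ccccc34)cc2n1)S(=O)(=O)c1ccccc1` gives 3700 nM. Among these, compound 3 sits second highest: its number and that of compound 1 are not separated beyond the scatter, while compound 2 is lower, as shown by an 8.2-fold higher number from compound 2 to compound 3 (0.91 log units; beyond the scatter) read in reverse. The steps measured so far, a 14-fold lower number from compound 1 to compound 2 (1.13 log units; beyond the scatter), a 1.7-fold lower number from compound 1 to compound 3 (0.22 log units; within the scatter) and an 8.2-fold higher number from compound 2 to compound 3 (0.91 log units; beyond the scatter), all exchange the whole group on the nitrogen; none alters a substituent on an aryl ring that is already present.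

Compound 4 `COc1ccc(S(=O)(=O)N(C)c2ccc3[nH]c(-c4n[nH]c5ccccc45)cc3n2)cc1OC` differs from compound 3 only in 3,4-dimethoxyphenyl in place of phenyl on a sulfonyl sulfur. Within the data shown here, no measured step covers a change of this kind, so no direction can be taken from the series. The expectation for compound 4 is therefore a step of a 1.2-fold lower number from compound 3 to compound 4 (0.09 log units; within the scatter) that does not go beyond the scatter. The estimated value for compound 4 in this assay is 3000 nM, with a range from 1000 nM to 9000 nM.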

Compound 4, half-maximal inhibitory concentration: 6320 nM
Beside the measured number, compound 4's estimate is 2.1-fold (0.32 log units) below it; measured number inside the range.
By their numbers in this assay, from the lowest: compound 2; then compounds 3, 1 and 4 (each within the scatter of the next).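

In this assay, among these compounds, a 1.7-fold higher number from compound 3 to compound 4 (0.23 log units; within the scatter) is the first step that keeps the sulfonyl link and changes only the aryl group on it, and the two compounds cannot be told apart. Within this pair, then, 3,4-dimethoxyphenyl in place of phenyl on a sulfonyl sulfur, with its 2 hydrogen-bond acceptors and larger heavy-atom count, leaves the number within the scatter. The data on hand offer no explanation for this result.

Still open, going by these compounds, is whether 4-chlorophenyl on the sulfonyl sulfur, the group carried on the carbonyl carbon of compound 2, would move the number beyond the scatter from compound 3. Also open, on these data alone, is how a carboxylic acid or an amine on that aryl ring would read out.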